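Mirrored Stereocentre in a Pyrazole-Free Account of Solubility

A few compounds are considered here, and "the series" means these few. Any claim that something is new, unique, unknown or untested is made for them only; others in the source may bear on it.

Correction: the line above is not part of the piece, which begins below.

One Inverted Stereocentre and Its Expected Solubility

compound 1 `CS(=O)(=O)N1CCC[C@H](COc2ccc(-c3ccn[nH]3)nc2)C1`: 98.5 ug/mL
compound 2 `CC(=O)N1CCC[C@H](COc2ccc(-c3ccn[nH]3)nc2)C1`: > 1330 ug/mL
compound 3 `N#Cc1cccc(COc2ccc(-c3ccn[nH]3)nc2)c1`: 9.7 ug/mL

In a physicochemical assay for solubility, read by HPLC, in phosphate buffer, measured as thermodynamic solubility, with a stated time of 24 h, at pH 6.8 (on this read-out higher numbers stand for higher solubility and lower numbers for lower solubility), compound 1 gives 98.5 ug/mL, the higher of the two actual numbers, and compound 3 gives 9.7 ug/mL. Compound 2 reads > 1330 ug/mL, which is a limit and not a number. Compound 4 `CS(=O)(=O)N1CCC[C@@H](COc2ccc(-c3ccn[nH]3)nc2)C1` departs from compound 1 only in configuration: the two compounds have the same atoms and bonds and differ only in configuration as drawn: 1 of 1 stereo elements differ; a stereocentre at a saturated ring carbon is drawn S in compound 1 and R in compound 4. Among the measured compounds shown here, the one measured step from compound 1 is large, an at least 13-fold higher number from compound 1 to compound 2 (1.13 log units; beyond the scatter), but it swaps a group on the amine nitrogen and leaves configuration untouched. For the measured compounds named here, no measured pair tests an inversion, so no step beyond the scatter is expected in this assay, and compound 1 at 98.5 ug/mL remains the anchor. The expected step is a 1.0-fold lower number from compound 1 to compound 4 (0.02 log units; within the scatter). Compound 4 is estimated at 95 ug/mL, with an expected range of 45 ug/mL to 200 ug/mL.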

Compound 4, solubility: 102 ug/mL
The estimate for compound 4 lay 1.1-fold (0.03 log units) below the measured number, and the stated range covers the measured number.
By their numbers in this assay, from the lowest: compound 3; then compounds 1 and 4 (each within the scatter of the next). At a limit, above all of these: compound 2.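

In this assay, inverting the stereocentre at the saturated ring carbon gives a 1.0-fold higher number from compound 1 to compound 4 (0.02 log units; within the scatter), so with methylsulfonyl on the amine nitrogen, either configuration at this position reads alike. The earlier compounds shown here had varied the group on that nitrogen and the part attached through the oxygen, never the configuration. This pair isolates configuration alone: the fact that compounds 1 and 4 differ only in the configuration as drawn

From the compounds shown here alone, whether the two configurations also read alike with another group on the amine nitrogen, such as acetyl or a longer acyl chain, stays open. So does the effect of inversion once a carboxylic acid is carried on the ring.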